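A few compounds are considered here, and "the series" means these few. Any claim that something is new, unique, unknown or untested is made for them only; others in the source may bear on it.

Compound 1, `COc1cc(-c2cc(/C=C/C(=O)c3ccc(Cl)c(Cl)c3)[nH]n2)cc(OC)c1OC`: 99%
Compound 2, `COc1ccc(C(=O)/C=C/c2cc(-c3cc(OC)c(OC)c(OC)c3)n[nH]2)cc1`: 101%

In a functional assay on A549 cells (Homo sapiens) for cytotoxicity, read by sulforhodamine B assay, with a stated time of 48 h, tested at 0.1 uM (on this read-out higher numbers stand for a weaker effect at the one concentration tested and lower numbers for a stronger effect), compound 1 gives 99% and compound 2 gives 101%. Compound 2 has the higher of the two numbers, but the step of a number 2 percentage points higher from compound 1 to compound 2 (within the scatter) lies within the scatter, so on this read-out the two compounds cannot be told apart: both sit close to the point at which the cells are as active as untreated ones.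

Compound 3, `COc1cc(-c2cc(/C=C/C(=O)c3ccc(F)c(F)c3)[nH]n2)cc(OC)c1OC`, has not yet been measured. It differs from compound 2 by 3,4-difluorophenyl in place of 4-methoxyphenyl on a carbonyl carbon. Among the compounds with values here, only one measured step bears on this change: the earlier exchange of the group on the carbonyl carbon, a number 2 percentage points higher from compound 1 to compound 2 (within the scatter), which moved the number by less than the scatter. Both measured compounds leave the cells almost untouched at the one concentration tested, and another exchange at the same place is expected to do the same, with a number 1 percentage points lower from compound 2 to compound 3 (within the scatter). Compound 3 is therefore estimated at 100%, with a range from 88% to 110%.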

Compound 3, a percentage reported as activity, at one concentration (the size of the read-out at that concentration, not a potency): 98%
Compound 3: middle estimate off by 2 percentage points, on the high side; low and high end bracket the measured number.
By their numbers in this assay, from the lowest: compounds 3, 1 and 2 (each within the scatter of the next).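

With 3,4-difluorophenyl on the carbonyl carbon, a third group now sits at this position, and the exchange for 4-methoxyphenyl gives a number 3 percentage points lower from compound 2 to compound 3 (within the scatter), while the exchange for 3,4-dichlorophenyl gives a number 1 percentage points lower from compound 1 to compound 3 (within the scatter). Within the data shown here, the earlier pair compared only one halogen-bearing ring with one methoxy-bearing ring, whereas these steps add a comparison between fluorine and chlorine at the same ring positions, and in this assay none of the three compounds can be told apart from the others. Nothing measured here explains this sameness.

As far as these compounds go, a single concentration gives no potency, so it remains open whether these three groups would separate at higher concentrations, where the cells might respond at all. Also open, from the compounds shown here alone, is whether a group of a different kind on the carbonyl carbon, such as an aminophenyl, a carboxylic acid-bearing phenyl or a simple open alkyl chain in place of the aromatic ring, would move the number beyond the usual scatter.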